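A few compounds are considered here, and "the series" means these few. Any claim that something is new, unique, unknown or untested is made for them only; others in the source may bear on it.

In a physicochemical assay for solubility, in phosphate buffer, with a stated time of 2 h, at pH 6.5 (on this read-out higher numbers stand for higher solubility and lower numbers for lower solubility), compound 2 `CC1(C)c2cc(Cl)ccc2C(=O)N1c1cncc(OC2CN(C(=O)c3ncccc3Cl)C2)c1` gives 20 ug/mL as its reading, within the scatter of compound 1 `CCS(=O)(=O)N1CCC(c2cncc(N3C(=O)c4ccc(Cl)cc4C3(C)C)c2)CC1` with 39 ug/mL measured, while compound 3 `Cn1cc(C(=O)N2CC3(C2)CN(c2cncc(N4C(=O)c5ccc(Cl)cc5C4(C)C)c2)C3)cn1` with 44 ug/mL measured stands higher than compound 2 by more than the scatter. Compound 4 `Cn1cc(C(=O)N2CC(Oc3cncc(N4C(=O)c5ccc(Cl)cc5C4(C)C)c3)C2)cn1` differs from compound 2 by one swap 1-methyl-1H-pyrazol-4-yl in place of 3-chloropyridin-2-yl on a carbonyl carbon that puts 1-methyl-1H-pyrazol-4-yl in place of 3-chloropyridin-2-yl on a carbonyl carbon. Within the data shown here, no measured pair isolates this swap. Among the measured compounds shown here, the only guide is compound 3, which carries the same (1-methyl-1H-pyrazol-4-yl)carbonyl on a different remainder and reads 44 ug/mL there. A modest rise is expected in this assay with a 2.0-fold higher number from compound 2 to compound 4 (0.30 log units; within the scatter) as the estimated step, near the edge of the scatter. For compound 4 the estimate is 40 ug/mL with an expected range from 18 ug/mL to 88 ug/mL overall.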

Compound 4, solubility: 310 ug/mL
The estimate for compound 4 lay 7.8-fold (0.89 log units) below the measured number; measured number outside the range, above it.
By their numbers in this assay, from the lowest: compounds 2, 1 and 3 (each within the scatter of the next, the first and the last beyond it); then compound 4.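

On a carbonyl carbon whose other neighbour is an amide-type nitrogen in a ring, this pair isolates a single change, which compound 3 alone could not do. In this assay, 1-methyl-1H-pyrazol-4-yl in place of 3-chloropyridin-2-yl gives a 16-fold higher number from compound 2 to compound 4 (1.19 log units; beyond the scatter) and moves this series far beyond the scatter, so the group on this carbonyl strongly affects the reading. No measurement here gives a reason for the size of this step.

On these data alone, whether the same swap gives a similar step on the remainders of compound 1 or compound 3 stays open. So does how a plain phenyl or a morpholine at this carbonyl would read.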